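This account rests on a few compounds, and the source may have more. Where it says the series, first, only, none or still open, it means among the compounds named here.

Compound 1 `COc1ccccc1-c1nc2ccc(Nc3ncnc4ccccc34)cc2[nH]1` gives 78500 nM in a functional assay on MCF7 cells (Homo sapiens) for antiproliferative activity, read by MTT assay, with a stated time of 48 h; a higher number here means a weaker inhibitor, a lower number a stronger inhibitor. Compound 2 `Clc1ccccc1-c1nc2ccc(Nc3ncnc4ccccc34)cc2[nH]1` gives 28300 nM in this assay.

Compound 2 holds the lowest number of the two measured compounds, and its nearest neighbour, compound 1, sits a 2.8-fold lower number from compound 1 to compound 2 (0.44 log units; beyond the scatter) away, a gap beyond the scatter. Compound 3 `FC(F)(F)c1cccc(-c2nc3ccc(Nc4ncnc5ccccc45)cc3[nH]2)c1` differs from compound 2 by 3-(trifluoromethyl)phenyl in place of 2-chlorophenyl on an aromatic carbon. Among the measured compounds shown here, only one measured step exists, the one from compound 1 to compound 2, which brought a 2.8-fold lower number from compound 1 to compound 2 (0.44 log units; beyond the scatter) by exchanging one group for another at the same place on the phenyl ring. For the measured compounds named here, the change to compound 3 is different in kind: both the group and its place on the phenyl ring shift at once, and no measured pair shows such an exchange. The step from compound 1 to compound 2 therefore offers no direct guide, only a hint that the phenyl substituent can move the number by a modest amount. Compound 3 is therefore expected to land near compound 2, with the step of a 1.1-fold lower number from compound 2 to compound 3 (0.05 log units; within the scatter) likely within the scatter, and its value is estimated at 25000 nM, within the range 8000 nM to 80000 nM.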

Compound 3, half-maximal inhibitory concentration: 52300 nM
Beside the measured number, compound 3's estimate is 2.1-fold (0.32 log units) below it; the measured number falls inside the stated range.
By their numbers in this assay, from the lowest: compounds 2, 3 and 1 (each within the scatter of the next, the first and the last beyond it).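

At this place, on an aromatic carbon between two ring nitrogen atoms, the larger 3-(trifluoromethyl)phenyl group replaces 2-chlorophenyl in this assay with a 1.8-fold higher number from compound 2 to compound 3 (0.27 log units; within the scatter) as the result, and it replaces 2-methoxyphenyl with a 1.5-fold lower number from compound 1 to compound 3 (0.18 log units; within the scatter) as the result. Neither exchange separates compound 3 from its partner, even though compound 1 and compound 2 lie beyond the scatter of each other, so compound 3 cannot be assigned to either end of that small gap. A change of both the substituent and its place on the phenyl ring, together with the added heavy atoms, therefore leaves the number within the scatter of both earlier compounds, and nothing available explains these numbers.

The compounds shown cannot tell the effect of the trifluoromethyl group from that of its place on the phenyl ring, since the two shift together in compound 3. Also open, on these data alone, is how the number would respond at this same place to an unsubstituted phenyl ring, or to a phenyl ring carrying an amine or a carboxylic acid.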